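Chain homologation of the hydroxyalkyl side chain

This account rests on a few compounds, and the source may have more. Where it says the series, first, only, none or still open, it means among the compounds named here.

Compound 1 `CCCCCn1nc2ccccc2c1OC` gives 3880 nM in an assay on isolated protein (urine) for inhibition of Myeloperoxidase (Homo sapiens), read by spectrophotometry; on this read-out higher numbers stand for weaker inhibition and lower numbers for stronger inhibition. Among the measured compounds shown here, compound 2 `COc1c2ccccc2nn1CCCCO` gives 1790 nM in this assay, the lowest of the two numbers measured so far; the step of a 2.2-fold lower number from compound 1 to compound 2 (0.34 log units; beyond the scatter) is modest but beyond the scatter. Compound 3 `COc1c2ccccc2nn1CCCCCO` carries hydroxymethyl in place of hydroxy on a saturated chain carbon, four bonds along the chain from an aromatic nitrogen. For the measured compounds named here, the single measured step concerns only the exchange of methyl for hydroxy at the chain end, so nothing bears directly on lengthening the chain by one carbon. The step from compound 2 to compound 3 is therefore expected to stay within the scatter, a 1.0-fold higher number from compound 2 to compound 3 (0.00 log units; within the scatter). Compound 3 is estimated at 1800 nM, with a range from 800 nM to 4000 nM.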

Compound 3, half-maximal inhibitory concentration: 1540 nM
Estimate against measurement, compound 3: 1.2-fold (0.07 log units) above; measured number inside the range.
By their numbers in this assay, from the lowest: compounds 3 and 2 (each within the scatter of the next); then compound 1.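

Hydroxymethyl in place of hydroxy on this saturated chain carbon, four bonds along the chain from an aromatic nitrogen, gives in this assay a 1.2-fold lower number from compound 2 to compound 3 (0.07 log units; within the scatter), so the extra chain carbon brings no change that can be told from the scatter. Hydroxy in place of hydrogen on a saturated chain carbon, five bonds along the chain from an aromatic nitrogen, gives a 2.5-fold lower number from compound 1 to compound 3 (0.40 log units; beyond the scatter), which shows that the gain from a hydroxy also appears on this chain. No available evidence bears on the reason for these numbers.

The compounds shown leave open whether a longer chain, or an amine or a carboxylic acid in place of the hydroxy, would move the number beyond the scatter.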